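Aryl substituent change on the shared core

A few compounds are considered here, and "the series" means these few. Any claim that something is new, unique, unknown or untested is made for them only; others in the source may bear on it.

Compound 1 `Fc1ccc(/C=C2\CCN=C2c2cccnc2)cc1`: > 10000 nM
Compound 2 `N#Cc1ccc(/C=C2\CCN=C2c2cccnc2)cc1`: > 10000 nM

Both measured compounds sit at the upper limit of an assay for displacement of a labelled ligand from Nicotinic acetylcholine receptor alpha8 subunit (Periplaneta americana), read by scintillation counting, with a stated time of 2 h, at 24 degrees C; a lower number here means a stronger inhibitor, a higher number a weaker inhibitor. Compound 1 gives > 10000 nM, which is a limit of the assay and not a number. Compound 2 gives > 10000 nM, again only a limit. The step from compound 1 to compound 2, a step that the two limits leave unreadable from compound 1 to compound 2, is therefore unreadable, as both values sit at the limit of > 10000 nM in this assay, at which 2 of the 2 values shown sit.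

Compound 3 `CN(C)c1ccc(/C=C2\CCN=C2c2cccnc2)cc1` differs from compound 2 by dimethylamino in place of cyano on an aromatic carbon. Going by the values given here, the one measured step concerns a change at the same aromatic carbon, but its size cannot be read, so it supplies neither a direction nor a magnitude for the present change. With compound 2 at a limit, the expectation for compound 3 is that it too remains at or near the limit of this assay, and the estimated step that the limit leaves unreadable from compound 2 to compound 3 is taken as none that can be read beyond the scatter. Compound 3 is expected to give about 15000 nM, within 3000 nM to 60000 nM, most likely reported once more as a limit.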

Compound 3, half-maximal inhibitory concentration: 5490 nM
Compound 3: the middle estimate sits 2.7-fold (0.44 log units) above what was measured; low and high end bracket the measured number.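

In this assay, going by these compounds alone, compound 3 gives 5490 nM, the only value shown that is a number. Dimethylamino is thus the one group at this aromatic carbon, para to a large group, that brings the series off the limit. Dimethylamino in place of cyano gives an at least 1.8-fold lower number from compound 2 to compound 3 (0.26 log units; that floor lies within the scatter), and dimethylamino in place of fluoro gives an at least 1.8-fold lower number from compound 1 to compound 3 (0.26 log units; that floor lies within the scatter); both floors lie within the scatter, so neither establishes a real difference on its own, though the true steps may be larger. The two steps can be read only as floors because the other two compounds remain at a limit: the limit of > 10000 nM in this assay, at which 2 of the 3 values shown sit.

The step between fluoro and cyano cannot be read, so the compounds shown put those two groups in no order. Also open, going by these compounds, is whether the readable value depends on dimethylamino itself or would hold for a primary amine, a pyrrolidine or a methoxy group at the same carbon, and how far any such group would take the series below the limit.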